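This account rests on a few compounds, and the source may have more. Where it says the series, first, only, none or still open, it means among the compounds named here.

Of the compounds shown here, two have so far been measured in a functional assay on BMDM cells (Mus musculus, strain C57BL/6) for inhibition, with a stated time of 2 days; a higher number here means a weaker inhibitor, a lower number a stronger inhibitor. Compound 1 `CCOC(=O)c1sc(NC(=O)Cn2cc(-c3ccc(Cl)cc3)nn2)nc1C` gives 180 nM in this assay, and compound 2 `COc1ccc(-c2cn(CC(=O)Nc3nc(C)cs3)nn2)cc1` gives 3890 nM. Compound 2 therefore stands at the higher of the two numbers, and its gap to compound 1 lies beyond the usual scatter of this assay. Compound 3 `Cc1csc(NC(=O)Cn2cc(-c3ccc(Cl)cc3)nn2)n1` remains to be measured. It differs from compound 2 in one place: chloro in place of methoxy on an aromatic carbon. Among the measured compounds shown here, compound 1 also carries chloro on its six-membered aromatic ring of carbon only, but it differs from compound 3 in its core as well, so no measured pair isolates this change. Because compound 1 gives 180 nM in this assay, the step of a 4.3-fold lower number from compound 2 to compound 3 (0.64 log units; beyond the scatter) is expected to lower the number, though the additional difference in compound 1 leaves the size uncertain. Compound 3 is estimated at 900 nM, with a range from 250 nM to 3500 nM.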

Compound 3, half-maximal inhibitory concentration: 520 nM
Compound 3: middle estimate off by 1.7-fold (0.24 log units), on the high side, within the range that was stated.
By their numbers in this assay, from the lowest: compound 1; then compound 3; then compound 2.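

In this assay, chloro in place of methoxy on the six-membered aromatic ring of carbon only, para to a large group, gives a 7.5-fold lower number from compound 2 to compound 3 (0.87 log units; beyond the scatter). This isolates the effect of that one change, which the gap between the two earlier compounds could not do because they differed in more than one place. Compound 3 also isolates the ester on the core, since hydrogen in place of ethoxycarbonyl on an aromatic carbon gives a 2.9-fold higher number from compound 1 to compound 3 (0.46 log units; beyond the scatter), and no measurement shown here explains either step.

Going by these compounds, with only methoxy and chloro compared on the six-membered ring, it remains open how fluoro, trifluoromethyl or a nitrile would rank there. On these data alone, it is equally open whether a carboxylic acid or a primary amide could stand in for the ethoxycarbonyl of compound 1.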